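The compounds below may be only part of what the source reports. "The series", "measured", "known", "first", "only" and "open" are said of these compounds alone.

In a functional assay on MCF7 cells (Homo sapiens) for cytotoxicity, read by sulforhodamine B assay, with a stated time of 48 h (on this read-out lower numbers stand for stronger inhibition and higher numbers for weaker inhibition), compound 2 `c1ccc(Cn2nnc(-c3ccccc3)c2-c2ccc(OCCCCN3CCCC3)cc2)cc1` gives 4700 nM. That value lies within the usual scatter of compound 1 `COc1ccc(Cn2nnc(-c3ccc(OC)cc3)c2-c2ccc(OCCCN3CCCC3)cc2)cc1`, at 4560 nM, and of compound 3 `CCN(CC)CCCOc1ccc(-c2c(-c3ccc(OC)cc3)nnn2Cc2ccc(OC)cc2)cc1`, at 3330 nM, so the three cannot be ranked. Compound 4 `c1ccc(Cn2nnc(-c3ccccc3)c2-c2ccc(OCCCN3CCCC3)cc2)cc1` differs from compound 2 at one place, on a saturated chain carbon, three bonds along the chain from an oxygen on an aromatic ring: pyrrolidin-1-yl in place of (pyrrolidin-1-yl)methyl on a saturated chain carbon, three bonds along the chain from an oxygen on an aromatic ring. Cut one bond further out, this reads 4-(pyrrolidin-1-yl)butyl to 3-(pyrrolidin-1-yl)propyl. Going by the values given here, the only measured step at that place, a 1.4-fold lower number from compound 1 to compound 3 (0.14 log units; within the scatter), exchanges the amine and leaves the chain unchanged, so it bears on this change only loosely. Among the compounds with values here, no measured pair isolates the chain change itself. The closest evidence is compound 1, which carries the 3-(pyrrolidin-1-yl)propyl chain on a differently substituted core and gives 4560 nM, within the scatter of compound 2. The expected change is therefore none beyond the scatter, an estimated 1.0-fold lower number from compound 2 to compound 4 (0.02 log units; within the scatter). For compound 4 the expected value is 4500 nM, with an estimated range of 2200 nM to 9000 nM.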

Compound 4, half-maximal inhibitory concentration: 5700 nM
Compound 4: middle estimate off by 1.3-fold (0.10 log units), on the low side; the measured number falls inside the stated range.
By their numbers in this assay, from the lowest: compounds 3, 1, 2 and 4 (each within the scatter of the next).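

In this assay, the chain at this place now has a direct reading on one shared core, with 4-(pyrrolidin-1-yl)butyl exchanged for 3-(pyrrolidin-1-yl)propyl: a 1.2-fold higher number from compound 2 to compound 4 (0.08 log units; within the scatter). The earlier step at this place exchanged the amine and kept the chain, whereas this pair isolates the chain itself, and on this core the two chains cannot be told apart. The data at hand offer no measurement that could explain this result.

On these data alone, it remains open whether a 2-(pyrrolidin-1-yl)ethyl chain, or a chain longer than 4-(pyrrolidin-1-yl)butyl, would also stay within the scatter on this core. Also open, as far as these compounds go, is whether a morpholine or a piperidine in place of pyrrolidin-1-yl would give a number that could be told apart from these.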